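Two limits on the core, then a shifted nitrile

The source may hold more compounds than are shown below. What is called first, only, known or untested is meant among the compounds shown, and "the series" means these compounds.

Measured compounds:
compound 1, `Cn1c(=S)n(Cc2ccccc2C#N)c2c(N3CCC[C@@H](N)C3)ccnc21`, in an assay on isolated protein for inhibition of Dipeptidyl peptidase 9 (Homo sapiens), read by luminescence, with a stated time of 15 min; on this read-out lower numbers stand for stronger inhibition and higher numbers for weaker inhibition: > 100000 nM
compound 2, `Cn1c(=O)n(Cc2cccc(C#N)c2)c2c(N3CCC[C@@H](N)C3)ccnc21`, in this assay: > 100000 nM

Compound 1 gives in this assay only the limit of the assay, > 100000 nM, and no number. Compound 2 likewise gives only the limit, > 100000 nM, and no number. Among the measured compounds shown here, these two compounds differ in more than one place, so no step between them can be measured; what their two values show is that both sit at the same limit, which is the point noted as the limit of > 100000 nM in this assay, at which 2 of the 2 values shown sit. Compound 2 therefore stands nowhere on a scale of numbers: it is known only to be weaker than the assay can report.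

Compound 3, `Cn1c(=O)n(Cc2ccc(C#N)cc2)c2c(N3CCC[C@@H](N)C3)ccnc21`, has not been measured in this assay. It differs from compound 2 by 4-cyanophenyl in place of 3-cyanophenyl on a saturated chain carbon bound to an aromatic nitrogen, a rearrangement that keeps every atom and changes only where the nitrile sits on the benzyl group. For the measured compounds named here, with no measured step to lean on, and with both compounds at the limit, the expectation is that this change brings no shift beyond the scatter, so that the step from compound 2 to compound 3 is estimated as a number no higher from compound 2 to compound 3 (the limit leaves the size open). Compound 3 is accordingly expected to give in this assay about 100000 nM, within the range 30000 nM to 300000 nM, and most likely again only a limit.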

Compound 3, half-maximal inhibitory concentration: > 100000 nM
Compound 3 ended at the assay's limit (the forecaster's own chance of this, stated with the estimate: 80%); the middle value lies on the limit itself.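

Compound 2 and compound 3 differ in one place, but no step can be read between them in this assay, because each gives only a limit and not a number: the limit of > 100000 nM in this assay, at which 3 of the 3 values shown sit. The compounds shown leave open how strongly any of them inhibits, and whether 4-cyanobenzyl in place of 3-cyanobenzyl changes the read-out at all.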